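The source may report more compounds than this note shows. Statements on the series, on what has been measured and on what is new or still open speak of the compounds shown alone.

Measured compounds in a functional assay on CHO-K1 cells for antagonist activity at C-X-C chemokine receptor type 3 (Homo sapiens), read by FLIPR, with a stated time of 10 min, in the presence of a further agent that is not named here; on this read-out lower numbers stand for stronger inhibition and higher numbers for weaker inhibition:
compound 1 `COC1CCN(CC(=O)N2CCN(c3sc(C(F)(F)F)nc3-c3nc4ccccc4[nH]3)C[C@H]2C)C1`, 42 nM
compound 2 `Cc1nn(CC(=O)N2CCN(c3sc(C(F)(F)F)nc3-c3nc4ccccc4[nH]3)C[C@H]2C)cc1CN(C)C`, 2.7 nM
compound 3 `C[C@@H]1CN(c2sc(C(F)(F)F)nc2-c2nc3ccccc3[nH]2)CCN1C(=O)Cn1cccn1`, 13 nM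

Compound 3 stands second highest of the three numbers: a 3.2-fold lower number from compound 1 to compound 3 (0.51 log units; beyond the scatter), while a 4.8-fold higher number from compound 2 to compound 3 (0.68 log units; beyond the scatter). Compound 4 `C[C@@H]1CN(c2sc(C(F)(F)F)nc2-c2nc3ccccc3[nH]2)CCN1C(=O)Cn1cc(Cl)cn1` differs from compound 3 by chloro in place of hydrogen on an aromatic carbon. All three measured steps, a 16-fold lower number from compound 1 to compound 2 (1.19 log units; beyond the scatter), a 3.2-fold lower number from compound 1 to compound 3 (0.51 log units; beyond the scatter) and a 4.8-fold higher number from compound 2 to compound 3 (0.68 log units; beyond the scatter), exchange the whole group on the saturated chain carbon bound to the carbonyl carbon; none adds a single atom to the 1H-pyrazol-1-yl ring, so none bears directly on this change. The closest guide is a 4.8-fold higher number from compound 2 to compound 3 (0.68 log units; beyond the scatter), where the pyrazole carried further groups and the number was lower. A lone chloro is a far smaller change, so in this assay a step within the scatter, or at most a small lowering, is expected: a 1.4-fold lower number from compound 3 to compound 4 (0.16 log units; within the scatter). Compound 4 is estimated at 9 nM, with a range from 3.5 nM to 25 nM.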

Compound 4, half-maximal inhibitory concentration: 1.7 nM
Compound 4: middle estimate off by 5.3-fold (0.72 log units), on the high side; measured number below the stated range.
By their numbers in this assay, from the lowest: compounds 4 and 2 (each within the scatter of the next); then compound 3; then compound 1.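

In this assay, one chloro on this aromatic carbon of the pyrazole moves the number beyond the scatter (a 7.6-fold lower number from compound 3 to compound 4 (0.88 log units; beyond the scatter)), so this position responds to a single heavy atom, which the whole-group exchanges could not show. The 4-chloro-1H-pyrazol-1-yl group is not separated from the larger 4-((dimethylamino)methyl)-3-methyl-1H-pyrazol-1-yl group (a 1.6-fold lower number from compound 2 to compound 4 (0.20 log units; within the scatter)), yet it stands well clear of 3-methoxypyrrolidin-1-yl (a 25-fold lower number from compound 1 to compound 4 (1.39 log units; beyond the scatter)). Nothing at hand accounts for the chloro step.

Open, on these data alone, is whether bromo, methyl or a nitrile on the same carbon would match chloro.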